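Compound 3 to compound 4: ester out, sulfo chain in

A few compounds are considered here, and "the series" means these few. Any claim that something is new, unique, unknown or untested is made for them only; others in the source may bear on it.

Measured in a functional assay for inhibition; a higher number here means a weaker inhibitor, a lower number a stronger inhibitor:
- compound 1 `CC(C)(C)c1cc(-c2cc(=O)c3ccc(OCc4ccc(Cl)cc4)cc3o2)cc(C(C)(C)C)c1O`: 7000 nM
- compound 2 `CC(C)(C)c1cc(-c2cc(=O)c3ccc(OCC(=O)O)cc3o2)cc(C(C)(C)C)c1O`: 3000 nM; 100 nM (2 entries)
- compound 3 `CCOC(=O)COc1ccc2c(=O)cc(-c3cc(C(C)(C)C)c(O)c(C(C)(C)C)c3)oc2c1`: 3000 nM

Compound 3 holds the lower of the two single numbers, and compound 2 has no single number. Compound 4 `CC(C)(C)c1cc(-c2cc(=O)c3ccc(OCCCS(=O)(=O)O)cc3o2)cc(C(C)(C)C)c1O` swaps ethoxycarbonyl for 2-sulfoethyl on a saturated chain carbon bound to an oxygen on an aromatic ring: 2-sulfoethyl in place of ethoxycarbonyl on a saturated chain carbon bound to an oxygen on an aromatic ring. Going by the values given here, the only measured step at this chain is a 2.3-fold lower number from compound 1 to compound 3 (0.37 log units; beyond the scatter), modest but beyond the scatter. Compound 2 carries the same chain as compound 3 without the ethyl, but the several entries of compound 2 in this assay, 3000 nM; 100 nM (2 entries) disagree widely, so they hint at a lower number without fixing its size. A modest change is therefore expected, namely a 3.0-fold lower number from compound 3 to compound 4 (0.48 log units; beyond the scatter). Compound 4 is estimated at 1000 nM, within a range of 150 nM to 6000 nM.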

Compound 4, half-maximal inhibitory concentration: 500 nM
Beside the measured number, compound 4's estimate is 2.0-fold (0.30 log units) above it; the measured number falls inside the stated range.
By their numbers in this assay, from the lowest: compound 4; then compound 3; then compound 1.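

In this assay, putting 2-sulfoethyl in place of ethoxycarbonyl gives a 6.0-fold lower number from compound 3 to compound 4 (0.78 log units; beyond the scatter). Set against the 4-chlorophenyl group, the same 2-sulfoethyl gives a 14-fold lower number from compound 1 to compound 4 (1.15 log units; beyond the scatter). This position therefore accepts a sulfo group on the chain, and of the compounds with a single number, the end of the chain now spans a clear range of inhibition.

From the compounds shown here alone, whether an amine or a longer chain ending in the sulfo group would lower the number further remains open. How compound 4 compares with the free acid, compound 2, also stays unsettled: the several entries of compound 2 in this assay, 3000 nM; 100 nM (2 entries)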